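Moving from compound 2 to compound 3 in the cell assay

The source may report more compounds than this note shows. Statements on the series, on what has been measured and on what is new or still open speak of the compounds shown alone.

The series shares a common core carrying a dihydroxy acid side chain and a fluorophenyl ring, and differs in the amide substituent. Compound 1 `COc1cccc(CNC(=O)c2nn(-c3ccc(F)cc3)c(OC[C@@H](O)C[C@@H](O)CC(=O)O)c2C(C)C)c1` has been measured: in a functional assay on L6 cells (Rattus norvegicus) for inhibition (on this read-out lower numbers stand for stronger inhibition and higher numbers for weaker inhibition), compound 1 gives 8750 nM, a weak result on this scale. Within the data shown here, compound 2 `COc1ccccc1CNC(=O)c1nn(-c2ccc(F)cc2)c(OC[C@@H](O)C[C@@H](O)CC(=O)O)c1C(C)C` carries a closely related amide, but in this assay compound 2 gives "not determined" (no result reported), so its standing is unknown and no step from it can be computed.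

Compound 3 `CC(C)c1c(C(=O)N(C)Cc2ccc(F)cc2)nn(-c2ccc(F)cc2)c1OC[C@@H](O)C[C@@H](O)CC(=O)O` arises from compound 2 through a single change at the amide: (4-fluorobenzyl)(methyl)amino in place of (2-methoxybenzyl)amino on a carbonyl carbon. Without a value for compound 2 and without any measured step between neighbours, the direction of this change in this assay can only be guessed. The account treats it as a step of no settled direction, likely within or close to the scatter of the method, with compound 1 as the only anchor.

On that basis the inhibitory concentration of compound 3 in this assay is estimated at 9000 nM, expected to fall between 2500 nM and 35000 nM.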

Compound 3, half-maximal inhibitory concentration: 2800 nM
For compound 3 the middle estimate is 3.2-fold (0.51 log units) above the measured one; measured number inside the range.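

In this assay the amide position proves responsive to substitution: (4-fluorobenzyl)(methyl)amino in place of (3-methoxybenzyl)amino on the carbonyl carbon gives a 3.1-fold lower number from compound 1 to compound 3 (0.49 log units; beyond the scatter), a modest step and the only one that can be read here. The swap changes several things at once, as the methoxy group and the amide hydrogen leave while a fluorine and a methyl enter, and the step from compound 2, which has no reported result, cannot be read. Nothing at hand accounts for the lower number of compound 3.

From the compounds shown here alone, what stays open is which part of the swap carries the step, since the fluorine and the methyl are never varied apart from each other. (4-Fluorobenzyl)amino, which keeps the amide hydrogen, and (3-methoxybenzyl)(methyl)amino, which keeps the methoxy group, would separate the two, while a piperidine amide would show whether the benzyl group is needed at this position at all.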